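Hydroxy in place of nitro, starting from a limit

This account rests on a few compounds, and the source may have more. Where it says the series, first, only, none or still open, it means among the compounds named here.

Two compounds have readings so far in a functional assay on Malme-3M cells (Homo sapiens) for cytotoxicity, read by MTT assay, with a stated time of 6 days; a lower number here means that less compound is needed, a higher number that more compound is needed for the effect. Compound 1 (`COC(=O)c1c(-c2ccc(O)cc2)oc2ccc(OC)cc2c1=O`) gives > 25 ug/mL, which is a limit and not a number. Compound 2 (`COc1ccc2oc(-c3ccc([N+](=O)[O-])cc3)c(C(=O)O)c(=O)c2c1`) gives > 25 ug/mL, which is also a limit and not a number. Compound 2 therefore has no numerical position in the series, and the readings amount to the limit of > 25 ug/mL in this assay, at which 2 of the 2 values shown sit. For the measured compounds named here, no step between measured compounds is available to set a scale for a structural change.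

Compound 3 (`COc1ccc2oc(-c3ccc(O)cc3)c(C(=O)O)c(=O)c2c1`) has no reading yet. It differs from compound 2 as follows: hydroxy in place of nitro on an aromatic carbon. This places hydroxy in place of nitro on an aromatic carbon, para to a large group. As far as these compounds go, no step beyond the scatter is expected in this assay, and the direction remains open. This expectation rests on compound 2, whose reading of > 25 ug/mL is a limit. The expected change is a number no higher from compound 2 to compound 3 (the limit leaves the size open). A further report as a limit is the likelier outcome. For compound 3 the estimated value is 25 ug/mL, with an expected range from 12 ug/mL to 50 ug/mL.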

Compound 3, concentration for half-maximal effect: > 25 ug/mL
Compound 3 gave a limit, no number; the forecaster's own chance of this, stated with the estimate: 80%; the middle value lies on the limit itself.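

Compound 3 is reported as a limit, as are compound 1 and compound 2, so neither the change from compound 2 to compound 3 nor the change from compound 1 to compound 3 can be read as a step. The compounds shown leave open where any of the three would fall numerically, since all rest on one reading: the limit of > 25 ug/mL in this assay, at which 3 of the 3 values shown sit.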